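Growth inhibition notes: from compound 2 to compound 3

The compounds below may be only part of what the source reports. "The series", "measured", "known", "first", "only" and "open" are said of these compounds alone.

compound 1 `C=C[C@@](C)(/C=C/c1ccc(OC(=O)CCCCCCCCC)cc1)CCC=C(C)C` gives 42%
compound 2 `COc1ccccc1/C=C/[C@@](C)(/C=C/c1ccc(O)cc1)CCC=C(C)C` gives 38%

Both values come from a functional assay on OVCAR-5 cells (Homo sapiens) for inhibition, with a stated time of 48 h, tested at 50 uM; a higher number here means more inhibition of growth at the concentration tested, a lower number less inhibition of growth. Compound 2 stands at 38%, within the usual scatter of compound 1 at 42%, so the two cannot be ranked. The next compound to be measured is compound 3 `CC(C)=CCC[C@@](C)(/C=C/c1ccc(N)cc1)/C=C/c1ccc(O)cc1`, in which 4-aminophenyl takes the place of 2-methoxyphenyl on a double-bonded chain carbon bound to a double-bonded chain carbon (4-aminophenyl in place of 2-methoxyphenyl on a double-bonded chain carbon bound to a double-bonded chain carbon). The two measured compounds differ in more than one place, so the data offer no direct guide to this change. No step beyond the scatter is expected in this assay, and neither direction is favoured. The expected change is a number 2 percentage points higher from compound 2 to compound 3 (within the scatter). For compound 3 the estimated value is 40%, with an expected range of 22% to 58%.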

Compound 3, percent growth inhibition at one concentration: 16%
Compound 3: the middle estimate sits 24 percentage points above what was measured; measured number below the stated range.
By their numbers in this assay, from the lowest: compound 3; then compounds 2 and 1 (each within the scatter of the next).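

In this assay, replacing 2-methoxyphenyl with 4-aminophenyl on a double-bonded chain carbon bound to a double-bonded chain carbon gives a number 22 percentage points lower from compound 2 to compound 3 (beyond the scatter). For the compounds shown here, this is the first single-place comparison, and it shows that growth inhibition responds to the group at this position, which compound 1 and compound 2 could not show as they differ in more than one place. Nothing measured on the compounds explains the step.

Both groups carry one six-membered aromatic ring of carbon only, so the step may follow the amine, the loss of the methoxy group or the change in substituent placement, and these cannot be separated here. A plain phenyl group at this place would give a reference for telling them apart.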